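Swapping the Urea Aryl Group: Dichloro to Trifluoromethyl

The compounds below may be only part of what the source reports. "The series", "measured", "known", "first", "only" and "open" are said of these compounds alone.

Measured so far in a functional assay on Hs-578T cells (Homo sapiens) for inhibition, read by sulforhodamine B assay, with a stated time of 48 h, tested at 10 uM; a higher number here means a weaker effect of the compound at the concentration tested, a lower number a stronger effect:
- compound 1 `COc1cc(Cl)cc(-c2nn(-c3cccc(NC(=O)Nc4ccc(Cl)c(C(F)(F)F)c4)c3)cc2-c2ccncc2)c1` gives 14.6%
- compound 2 `COc1cc(Cl)cc(-c2nn(-c3cccc(NC(=O)Nc4cc(C(F)(F)F)cc(C(F)(F)F)c4)c3)cc2-c2ccncc2)c1` gives 5.82%
- compound 3 `COc1cc(Cl)cc(-c2nn(-c3cccc(NC(=O)Nc4ccc(Cl)c(Cl)c4)c3)cc2-c2ccncc2)c1` gives 28.5%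

All three share the same core and differ only in the aryl group carried on the urea nitrogen. On these numbers compound 3 stands highest, which in this assay means the weakest effect at the concentration tested; compound 1 lies nearest, and compound 2 is furthest away, both gaps beyond the scatter.

The next compound, compound 4 `COc1cc(Cl)cc(-c2nn(-c3cccc(NC(=O)Nc4cccc(C(F)(F)F)c4)c3)cc2-c2ccncc2)c1`, is reached from compound 3 by one change: 3-(trifluoromethyl)phenyl in place of 3,4-dichlorophenyl on an amide-type nitrogen. Within the data shown here, only one measured step speaks to this. a number 13.9 percentage points higher from compound 1 to compound 3 (beyond the scatter), so exchanging trifluoromethyl for chloro made the effect weaker by a modest amount. Among the measured compounds shown here, compound 4 reverses that exchange and at the same time drops the second chloro, which no measured pair isolates.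

The expectation is therefore a step downward from compound 3 of roughly the size seen before, a number 10.5 percentage points lower from compound 3 to compound 4 (beyond the scatter), toward the value of compound 1 rather than a return to compound 2. Compound 4 is estimated at 18%, with a range from 8% to 32%.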

Compound 4, a percentage reported as activity, at one concentration (the size of the read-out at that concentration, not a potency): 23.2%
Estimate against measurement, compound 4: 5.2 percentage points below, and the stated range covers the measured number.
By their numbers in this assay, from the lowest: compounds 2, 1, 4 and 3 (each within the scatter of the next, the first and the last beyond it).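

Exchanging the two chloro groups for a single trifluoromethyl gives a number 5.3 percentage points lower from compound 3 to compound 4 (within the scatter) in this assay, so 3-(trifluoromethyl)phenyl and 3,4-dichlorophenyl cannot be told apart on the urea nitrogen at this concentration. Hydrogen in place of chloro also gives no readable change, with a number 8.6 percentage points higher from compound 1 to compound 4 (within the scatter), whereas hydrogen in place of the second trifluoromethyl gives a number 17.4 percentage points higher from compound 2 to compound 4 (beyond the scatter) and is the only new step beyond the scatter, which shows that removing a group from this ring can matter for one group and remain unreadable for another. Nothing measured here accounts for that difference between the two removals.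

Compound 4 cannot be separated from compound 1 or compound 3, even though those two differ beyond the scatter, so a single further aryl group could help to show whether the remaining trifluoromethyl carries much of the effect. Still open, going by these compounds, is how an unsubstituted phenyl would read on the urea nitrogen, and how a ring bearing a nitrile, a methoxy group or a dimethylamino group would compare with compound 4.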